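The source may hold more compounds than are shown below. What is called first, only, known or untested is meant among the compounds shown, and "the series" means these compounds.

Measured so far in a functional assay on PC-3 cells (Homo sapiens) for antiproliferative activity, read by MTT assay, with a stated time of 72 h; on this read-out lower numbers stand for stronger inhibition and higher numbers for weaker inhibition:
compound 1, `CC(C)=CC(=O)Nc1cc2c(N3CCCc4ccccc43)ncnc2cc1O[C@@H]1CCOC1`: 9020 nM
compound 2, `C/C=C/C(=O)Nc1cc2c(N3CCCc4ccccc43)ncnc2cc1O[C@@H]1CCOC1`: 9350 nM

Among the measured compounds shown here, compound 2 and compound 1 sit together on this read-out; the single step between them, a 1.0-fold higher number from compound 1 to compound 2 (0.02 log units; within the scatter), is within the scatter, so neither can be set apart from the other.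

Compound 3, `CC/C=C/C(=O)Nc1cc2c(N3CCCc4ccccc43)ncnc2cc1O[C@@H]1CCOC1`, is the next member: methyl in place of hydrogen on a saturated chain carbon bound to a double-bonded chain carbon. For the measured compounds named here, the only step that bears on it is the one from compound 1 to compound 2, which also altered the alkenyl chain on the carbonyl and produced no change beyond the scatter. A further lengthening of that chain has no comparison of its own here, but on the evidence available no step beyond the scatter is expected in this assay.

Compound 3 is therefore estimated at 9500 nM, with a range from 4500 nM to 20000 nM. For compound 3 this means an expected step of a 1.0-fold higher number from compound 2 to compound 3 (0.01 log units; within the scatter).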

Compound 3, half-maximal inhibitory concentration: 14300 nM
Beside the measured number, compound 3's estimate is 1.5-fold (0.18 log units) below it; low and high end bracket the measured number.
By their numbers in this assay, from the lowest: compounds 1, 2 and 3 (each within the scatter of the next).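

In this assay, among the compounds shown here, the first comparison at this saturated chain carbon, methyl in place of hydrogen (a 1.5-fold higher number from compound 2 to compound 3 (0.18 log units; within the scatter)), stays within the scatter, so but-1-en-1-yl and prop-1-en-1-yl cannot be told apart. The unbranched but-1-en-1-yl set against the branched 2-methylprop-1-en-1-yl (a 1.6-fold higher number from compound 1 to compound 3 (0.20 log units; within the scatter)) is also within the scatter, so all three alkenyl chains on the carbonyl sit together in this small set. No supporting measurement bears on this result.

From the compounds shown here alone, whether any change at this position can move the number beyond the scatter remains open, for example a longer chain such as hex-1-en-1-yl or a dimethylamino group at the end of the chain. The compounds shown also leave open whether an unsubstituted vinyl group on the carbonyl would sit with these three.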